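Methoxy-to-methyl step on the carboxyphenyl end of the series

The source may report more compounds than this note shows. Statements on the series, on what has been measured and on what is new or still open speak of the compounds shown alone.

Compound 1 `COc1ccc(C(=O)O)cc1OCCCCOc1ccc(C(=O)CC(C)C)c(O)c1C` and compound 2 `COc1ccc(C(=O)O)cc1OCCCCOc1ccc(C(=O)CC2CCCC2)c(O)c1C` share one core. Within the data shown here, in an ADME assay (liver) for metabolic stability, with Liver microsome (Rattus norvegicus) as the target, read by LC-MS, using microsomes and NADPH, with stated times of 5 min and 60 min, tested at 4 uM (a higher number here means that more of the compound is left, a lower number that less of the compound is left), compound 1 gives 5% and compound 2 gives 14%; the two numbers lie within the scatter of each other, and the one measured step, a number 9 percentage points higher from compound 1 to compound 2 (within the scatter), concerns a different part of the molecule. Compound 3 `Cc1ccc(C(=O)O)cc1OCCCCOc1ccc(C(=O)CC2CCCC2)c(O)c1C` carries methyl in place of methoxy on an aromatic carbon. Among the measured compounds shown here, no measured step bears on this change, so no movement beyond the scatter is expected, and compound 3 is estimated at 16%, range 5% to 35%. The step thus expected is a number 2 percentage points higher from compound 2 to compound 3 (within the scatter).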

Compound 3, percent of the compound remaining: 9%
Estimate against measurement, compound 3: 7 percentage points above; measured number inside the range.
By their numbers in this assay, from the lowest: compounds 1, 3 and 2 (each within the scatter of the next).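

Among these compounds, on the carboxyphenyl end, the exchange of 5-carboxy-2-methoxyphenyl for 5-carboxy-2-methylphenyl gives the only step read at this position in this assay, a number 5 percentage points lower from compound 2 to compound 3 (within the scatter). Methoxy and methyl on this aromatic carbon therefore cannot be told apart in this read-out, at the low level of compound remaining seen across the series. Nothing at hand explains this reading.

The compounds shown leave open whether an amine or a chlorine atom on this aromatic carbon would give a step beyond the scatter. Also open, from the compounds shown here alone, is whether the same exchange reads alike with isopropyl in place of cyclopentyl on the chain.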